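The source may report more compounds than this note shows. Statements on the series, on what has been measured and on what is new or still open speak of the compounds shown alone.

Working notes on the hydrazone series. Two compounds have been run in a physicochemical assay on A549 cells for solubility, read by microscopy, with a stated time of 24 h; a higher number here means a weaker inhibitor, a lower number a stronger inhibitor. Compound 2 `O=C(N/N=C/c1ccccc1O)c1cc(-c2ccc(Cl)cc2)nn1Cc1ccccc1` gives 680 nM in this assay. Compound 1 `COc1ccc(-c2cc(C(=O)N/N=C/c3ccccc3O)n(Cc3ccc(Cl)nc3)n2)cc1` gives 570 nM in this assay. The two numbers lie within the scatter of each other, so the present data do not separate compound 2 from compound 1, and neither compound can be set above the other.

The next compound, compound 3 `COc1ccc(-c2cc(C(=O)N/N=C/c3ccccc3O)n(Cc3ccccc3)n2)cc1`, is not yet measured. It differs from compound 2 in one place: methoxy in place of chloro on an aromatic carbon. Among the compounds with values here, no single-change pair between measured compounds covers this exchange, so the step has to be judged from the two values at hand. Within the data shown here, the methoxyphenyl group of compound 3 is the one already present in compound 1, whose value of 570 nM in this assay sits beside that of compound 2.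

On that basis no step beyond the scatter is expected from compound 2 to compound 3, and the expected step reads a 1.1-fold lower number from compound 2 to compound 3 (0.04 log units; within the scatter). Compound 3 is estimated at 620 nM in this assay, with a range from 300 nM to 1300 nM.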

Compound 3, half-maximal inhibitory concentration: 840 nM
For compound 3 the middle estimate is 1.4-fold (0.13 log units) below the measured one, and the stated range covers the measured number.
By their numbers in this assay, from the lowest: compounds 1, 2 and 3 (each within the scatter of the next).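

In this assay the exchange of 4-chlorophenyl to 4-methoxyphenyl, on an aromatic carbon para to a large group, gives a 1.2-fold higher number from compound 2 to compound 3 (0.09 log units; within the scatter) and therefore does not separate chloro from methoxy at this position. The second single change now available, phenyl in place of 6-chloropyridin-3-yl on a saturated chain carbon bound to an aromatic nitrogen, gives a 1.5-fold higher number from compound 1 to compound 3 (0.17 log units; within the scatter) and so also stays short of a step that could be read as real, which means that neither of the two places varied so far has moved the number beyond the scatter in these compounds. No measurement at hand offers an explanation for these results.

Still open, going by these compounds, is whether a group of a different kind on the same aromatic carbon, such as an amine or a carboxylic acid, would give a step beyond the scatter in this assay where chloro and methoxy do not. Equally open is whether a longer chain in place of the saturated chain carbon bound to the aromatic nitrogen would change the number, since the compounds shown all carry that same single carbon.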